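Replacing Ethyl with Acetyl on the Amine of Compound 2

The source may report more compounds than this note shows. Statements on the series, on what has been measured and on what is new or still open speak of the compounds shown alone.

Two compounds share one core and have been tested in an assay on isolated protein for inhibition of ubiquitin carboxyl-terminal hydrolase 7 (Homo sapiens), with stated times of 30 min and 2 h; a lower number here means a stronger inhibitor, a higher number a weaker inhibitor:
Compound 1, `CN(C)Cc1ccc(-c2c3ncn(CC4(O)CCN(Cc5ccc(-c6ccco6)cc5Cl)CC4)c(=O)c3nn2C)cc1`, gives 131 nM.
Compound 2, `CCNCc1ccc(-c2c3ncn(CC4(O)CCN(Cc5ccc(-c6ccco6)cc5Cl)CC4)c(=O)c3nn2C)cc1`, gives 15.2 nM.

Going by the values given here, compound 2 has the lowest number of the two, and the only measured step, an 8.6-fold lower number from compound 1 to compound 2 (0.94 log units; beyond the scatter), separates it from compound 1. That step swaps one set of carbon groups on the amine nitrogen for another while the nitrogen stays an amine.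

Compound 3, `CC(=O)NCc1ccc(-c2c3ncn(CC4(O)CCN(Cc5ccc(-c6ccco6)cc5Cl)CC4)c(=O)c3nn2C)cc1`, is not yet measured. It differs from compound 2 by acetyl in place of ethyl on an amine nitrogen. The amine nitrogen of compound 2 thereby becomes part of an acetamido group. Among the compounds with values here, no measured step removes the amine in this way, so the single step from compound 1 to compound 2 offers only a loose guide: it shows that changes at this nitrogen can move the number well beyond the scatter. The estimate for compound 3 is therefore a weaker inhibitor than compound 2, a step of a 5.9-fold higher number from compound 2 to compound 3 (0.77 log units; beyond the scatter), with wide uncertainty. Compound 3 is expected to give about 90 nM, within a range from 15 nM to 500 nM.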

Compound 3, half-maximal inhibitory concentration: 46.1 nM
Compound 3: the middle estimate sits 2.0-fold (0.29 log units) above what was measured, and the stated range covers the measured number.
By their numbers in this assay, from the lowest: compound 2; then compound 3; then compound 1.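

In this assay, the earlier pair varied only the carbon groups on an amine nitrogen, whereas compound 3 brings a carbonyl onto that nitrogen, turning ethylamino into acetamido, and the result is a 3.0-fold higher number from compound 2 to compound 3 (0.48 log units; beyond the scatter). The nitrogen therefore need not stay an amine for the inhibitor to keep a number in the range of this small set: set against the dimethylamino group, the acetamido group gives a 2.8-fold lower number from compound 1 to compound 3 (0.45 log units; beyond the scatter). The order at this position also does not divide simply into amines and amides, since one amine, compound 2, has a lower number than the acetamido compound 3, while another amine, compound 1, has a higher one.

Nothing measured here bears on why the numbers fall in this order. Still open, as far as these compounds go, is how the number would respond to an unsubstituted aminomethyl group, a longer chain such as propyl on the amine, a longer acyl group such as propanoyl, or a methanesulfonyl group on the same nitrogen, and whether any of these would fall below the number of compound 2.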